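A Larger Aryl Group on the Carbonyl of Compound 2

The source may report more compounds than this note shows. Statements on the series, on what has been measured and on what is new or still open speak of the compounds shown alone.

Compound 2 `Cc1cc(C)cc(C(=O)Nc2cccc(-c3oc4cc(-c5ccc(F)cc5)ccc4c(=O)c3O)c2)c1` carries a 3,5-dimethylphenyl group on a carbonyl carbon of a shared core. In a functional assay on HepG2 cells (Homo sapiens) for antiproliferative activity, read by CCK-8 assay, with a stated time of 72 h (on this read-out lower numbers stand for stronger inhibition and higher numbers for weaker inhibition), compound 2 gives 13400 nM, one of only two numbers shown and level with compound 1 `O=C(Nc1cccc(-c2oc3cc(-c4ccc(F)cc4)ccc3c(=O)c2O)c1)c1ccc(Br)cc1`, which gives 13900 nM; the step of a 1.0-fold lower number from compound 1 to compound 2 (0.02 log units; within the scatter) lies within the scatter. Compound 3 `O=C(Nc1cccc(-c2oc3cc(-c4ccc(F)cc4)ccc3c(=O)c2O)c1)c1ccc(-c2ccccc2)cc1` differs from compound 2 by 4-phenylphenyl in place of 3,5-dimethylphenyl on a carbonyl carbon. Going by the values given here, only the step from compound 1 to compound 2 bears on this change, and it was flat, so for compound 3 a step of a 1.0-fold lower number from compound 2 to compound 3 (0.01 log units; within the scatter) in this assay is expected, nothing beyond the scatter. The estimate for compound 3 is 13000 nM, ranging from 5000 nM to 35000 nM.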

Compound 3, half-maximal inhibitory concentration: 88500 nM
Beside the measured number, compound 3's estimate is 6.8-fold (0.83 log units) below it, outside the stated range (above it).
By their numbers in this assay, from the lowest: compounds 2 and 1 (each within the scatter of the next); then compound 3.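

In this assay, the position on the carbonyl carbon turns out not to be flat: 4-phenylphenyl in place of 3,5-dimethylphenyl gives a 6.6-fold higher number from compound 2 to compound 3 (0.82 log units; beyond the scatter). Phenyl in place of bromo on an aromatic carbon gives a 6.4-fold higher number from compound 1 to compound 3 (0.80 log units; beyond the scatter), so the group with two aromatic rings stands apart from the two single-ring groups, which read level with each other. No evidence here explains this difference. Whether the second ring itself drives the change remains open, since only three groups are shown. A cyclohexyl group, a methyl group or an aminomethyl group on this carbonyl could help settle that.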